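Trimming a Long Chain on Two Different Cores

The source may hold more compounds than are shown below. What is called first, only, known or untested is meant among the compounds shown, and "the series" means these compounds.

The three measured compounds:
- compound 1, `CCCCCCCCCCCCCN1NN=C(NC(=O)Nc2c(C(C)C)cccc2C(C)C)N1`: 9 nM
- compound 2, `CCCCCCCCCCCCCCN1NN=C(NC(=O)Nc2c(C(C)C)cccc2C(C)C)N1`: 12 nM
- compound 3, `CCCCCCCCCCCCCc1cc(NC(=O)Nc2c(C(C)C)cccc2C(C)C)on1`: 13 nM

All three were tested in an assay on microsomes from intestine for inhibition of acyl-CoA:cholesterol acyltransferase (Oryctolagus cuniculus); on this read-out lower numbers stand for stronger inhibition and higher numbers for weaker inhibition. Compound 1 and compound 2 share one core and differ only at the far end of a long saturated chain: hydrogen in place of methyl on a saturated chain carbon, ten or more bonds along the chain from an amine nitrogen in a ring. That change gave a 1.3-fold lower number from compound 2 to compound 1 (0.12 log units; within the scatter), so the two numbers are indistinguishable within the usual scatter.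

Compound 3 carries a different core; the difference between the two cores is not broken down here. Its value and that of compound 2 lie within the scatter of each other, so the data show only that both are close.

Compound 4, `CCCCCCCCCCCCc1cc(NC(=O)Nc2c(C(C)C)cccc2C(C)C)on1`, has not yet been measured. It differs from compound 3 by hydrogen in place of methyl on a saturated chain carbon, ten or more bonds along the chain from an aromatic carbon. Going by the values given here, this is the same kind of change as the one from compound 2 to compound 1, but not the same: there the chain ran from an amine nitrogen in a ring, whereas here it runs from an aromatic carbon.

Given that, the step from compound 3 to compound 4 in this assay is expected to be small, about a 1.2-fold lower number from compound 3 to compound 4 (0.07 log units; within the scatter), because a 1.3-fold lower number from compound 2 to compound 1 (0.12 log units; within the scatter) was itself within the scatter. Compound 4 is therefore estimated at 11 nM, with a likely range from 5 nM to 25 nM.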

Compound 4, half-maximal inhibitory concentration: 19 nM
For compound 4 the middle estimate is 1.7-fold (0.24 log units) below the measured one; low and high end bracket the measured number.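

In this assay, hydrogen in place of methyl on a saturated chain carbon, ten or more bonds along the chain from an aromatic carbon, gives a 1.5-fold higher number from compound 3 to compound 4 (0.16 log units; within the scatter). On paper, this step and the matching one on the other core point in opposite directions, but neither step nor the gap between them stands clear of the ordinary spread of repeated measurements: the same change on two cores in this assay, a 1.3-fold lower number (0.12 log units; within the scatter) from compound 2 to compound 1 and a 1.5-fold higher number (0.16 log units; within the scatter) from compound 3 to compound 4, 1.9-fold (0.29 log units) apart, within the scatter of two such steps. Going by these compounds alone, this shows that, on both cores, shortening a chain that is already long by this one unit has no effect that can be told apart from the scatter, so the two cores agree in that limited sense, but it does not show that the change has no effect at all, or that the core has no influence on it, since each core offers only one small step.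

The chains shown differ only slightly in length, so it remains open what a much shorter chain, such as hexyl, would do on either core. Also open, going by these compounds, is whether an amine or a carboxylic acid in place of that methyl would give a step beyond the scatter, and whether such a step would carry from one core to the other.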